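A larger side group in a cell toxicity test

The source may report more compounds than this note shows. Statements on the series, on what has been measured and on what is new or still open speak of the compounds shown alone.

Compound 1 `COC(=O)CCN1CCN(c2c(F)cc3c(=O)c(C(=O)O)cn(C4CC4)c3c2OC)CC1C`: > 1000 ug/mL (a limit)
Compound 2 `COc1c(N2CCN(C/C(C)=N/O)C(C)C2)c(F)cc2c(=O)c(C(=O)O)cn(C3CC3)c12`: 177 ug/mL

For the measured compounds named here, in an ADME assay on Vero cells (Chlorocebus sabaeus) for cytotoxicity, read by MTT assay, with a stated time of 72 h (on this read-out higher numbers stand for lower toxicity in this test and lower numbers for higher toxicity in this test), compound 2 gives 177 ug/mL as the only true number so far. For compound 1, > 1000 ug/mL is a limit of the assay and not a number. Compound 3 `COc1c(N2CCN(CC/C(C)=N/O)C(C)C2)c(F)cc2c(=O)c(C(=O)O)cn(C3CC3)c12` differs from compound 2 in one place: a group of 5 heavy atoms (3 carbon, 1 nitrogen, 1 oxygen; no ring) in place of a group of 4 heavy atoms (2 carbon, 1 nitrogen, 1 oxygen; no ring), on a saturated chain carbon bound to an amine nitrogen in a ring. Going by the values given here, the one measured step at this place is an at least 5.6-fold lower number from compound 1 to compound 2 (0.75 log units; beyond the scatter), and it brought in a different kind of group, so it offers weak guidance. In this assay the expected change is a 1.2-fold higher number from compound 2 to compound 3 (0.09 log units; within the scatter), estimated to stay within the usual scatter. Compound 3 is expected at 220 ug/mL, with an estimated range from 80 ug/mL to 600 ug/mL in this test.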

Compound 3, half-maximal cytotoxic concentration: 44.2 ug/mL
Compound 3: the middle estimate sits 5.0-fold (0.70 log units) above what was measured; the whole stated range lies above it.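

In this assay, the larger group of 5 heavy atoms gives a 4.0-fold lower number from compound 2 to compound 3 (0.60 log units; beyond the scatter), so a small enlargement on this saturated chain carbon is enough to shift the number towards higher toxicity in this test. Across a different kind of side group, the comparison shows an at least 22-fold lower number from compound 1 to compound 3 (1.35 log units; beyond the scatter). Compound 1 marks a limit, not a true number, so that step has no fixed size: the limit of > 1000 ug/mL in this assay, at which 1 of the 3 values shown sits.

As far as these compounds go, whether a longer chain would lower the number further remains open, as does the effect of an amine or a carboxylic acid at this place.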